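From a Cyclic Amide to a Dipentyl Amide

A few compounds are considered here, and "the series" means these few. Any claim that something is new, unique, unknown or untested is made for them only; others in the source may bear on it.

Compound 1, `COc1ccc(/C=C/c2cc(OC)cc(OC)c2/C=C/C(=O)Nc2cc(OC)c(OC)c(OC)c2)cc1`: 8150 nM
Compound 2, `COc1ccc(/C=C/c2cc(OC)cc(OC)c2/C=C/C(=O)N2CCCC2)cc1`: 9280 nM
Compound 3, `COc1ccc(/C=C/c2cc(OC)cc(OC)c2/C=C/C(=O)NC(C)C)cc1`: 4020 nM

In a functional assay on B16-F10 cells (Mus musculus) for inhibition, read by MTT assay, with a stated time of 48 h (on this read-out higher numbers stand for weaker inhibition and lower numbers for stronger inhibition), compound 2 gives the highest of the three numbers. Compound 1 sits nearest to it, and the two lie within the usual scatter of each other. Compound 3 sits furthest from it, with a 2.3-fold lower number from compound 2 to compound 3 (0.36 log units; beyond the scatter); the related move from compound 1 to compound 3 gives a 2.0-fold lower number from compound 1 to compound 3 (0.31 log units; beyond the scatter).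

Compound 4, `CCCCCN(CCCCC)C(=O)/C=C/c1c(/C=C/c2ccc(OC)cc2)cc(OC)cc1OC`, has not yet been measured. It differs from compound 2 in one place: dipentylamino in place of pyrrolidin-1-yl on a carbonyl carbon. Among the measured compounds shown here, the only measured step that bears on it is the one from compound 2 to compound 3, which also replaces pyrrolidin-1-yl on the carbonyl carbon, but with a different group, so it guides only loosely. For the measured compounds named here, both measured steps were modest, and no step here exceeds a few multiples of the scatter. For compound 4 the expected shift in this assay is therefore small, a 1.3-fold lower number from compound 2 to compound 4 (0.12 log units; within the scatter), at most a modestly lower number. Compound 4 is estimated at 7000 nM, with a range from 2500 nM to 20000 nM.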

Compound 4, half-maximal inhibitory concentration: 9270 nM
Estimate against measurement, compound 4: 1.3-fold (0.12 log units) below, within the range that was stated.
By their numbers in this assay, from the lowest: compound 3; then compounds 1, 4 and 2 (each within the scatter of the next).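

Replacing pyrrolidin-1-yl, with 5 heavy atoms in one ring, by dipentylamino, with 11 heavy atoms and no ring, in this assay gives a 1.0-fold lower number from compound 2 to compound 4 (0.00 log units; within the scatter) and shows that on this carbonyl carbon opening the ring and adding bulk of this size does not move the number beyond the scatter. Measured against isopropylamino, the same group gives a 2.3-fold higher number from compound 3 to compound 4 (0.36 log units; beyond the scatter) and leaves compound 3 with the lowest number of the four, so open alkyl chains alone do not reproduce what compound 3 shows. The data offer no explanation for either step.

Still open, from the compounds shown here alone, is whether a longer chain on a nitrogen that keeps the amide hydrogen, such as pentylamino, would stay near compound 3 or join compound 4. Also open, going by these compounds, is where a ring with a second hetero atom, such as morpholin-4-yl, would fall.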